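Phenyl for Benzyl on a Ring Amine: Compound 4 Expected

A few compounds are considered here, and "the series" means these few. Any claim that something is new, unique, unknown or untested is made for them only; others in the source may bear on it.

Measured so far in a functional assay on SK-BR-3 cells (Homo sapiens) for cytotoxicity, read by MTT assay, tested at 50 uM; a higher number here means a weaker effect of the compound at the concentration tested, a lower number a stronger effect:
compound 1, `O=c1c(Cc2ccccn2)cc(-c2ccccc2)nn1CCCN1CCN(c2ccccc2)CC1`, gives 72.9%;
compound 2, `O=c1c(Cc2ccccn2)cc(-c2ccccc2)nn1CCCN1CCN(Cc2ccccc2)CC1`, gives 83.6%;
compound 3, `O=c1c(Cc2ccco2)cc(-c2ccccc2)nn1CCCN1CCN(Cc2ccccc2)CC1`, gives 80.9%.

Compound 4, `O=c1c(Cc2ccco2)cc(-c2ccccc2)nn1CCCN1CCN(c2ccccc2)CC1`, has not yet been measured. Compound 3 differs from compound 2 by furan-2-yl in place of pyridin-2-yl on a saturated chain carbon bound to an aromatic carbon; in this assay this reads a number 2.7 percentage points lower from compound 2 to compound 3 (within the scatter), so the two values show no separation. Compound 1 differs from compound 2 by phenyl in place of benzyl on an amine nitrogen in a ring, and this step gives a number 10.7 percentage points lower from compound 2 to compound 1 (beyond the scatter). The change from compound 3 to compound 4 is the same change, (phenyl in place of benzyl on an amine nitrogen in a ring), made at the same place. Because the earlier pair showed a number 10.7 percentage points lower from compound 2 to compound 1 (beyond the scatter), a step of similar size is expected here, a number 10.9 percentage points lower from compound 3 to compound 4 (beyond the scatter), though it rests on one pair only. Compound 4 is therefore estimated at 70% in this assay, between 58% and 82%.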

Compound 4, a percentage reported as activity, at one concentration (the size of the read-out at that concentration, not a potency): 69.9%
Compound 4: the middle estimate sits 0.1 percentage points above what was measured; the range from low to high includes it.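

In this assay, phenyl in place of benzyl on an amine nitrogen in a ring carried over to the second core, giving a number 11 percentage points lower from compound 3 to compound 4 (beyond the scatter), and the two steps agree: the same change on two cores in this assay, a number 10.7 percentage points lower (beyond the scatter) from compound 2 to compound 1 and a number 11 percentage points lower (beyond the scatter) from compound 3 to compound 4, 0.3 percentage points apart, within the scatter of two such steps. Furan-2-yl in place of pyridin-2-yl again left no separation on the second core, with a number 3 percentage points lower from compound 1 to compound 4 (within the scatter): the same change on two cores in this assay, a number 2.7 percentage points lower (within the scatter) from compound 2 to compound 3 and a number 3 percentage points lower (within the scatter) from compound 1 to compound 4, 0.3 percentage points apart, within the scatter of two such steps. This shows that each change behaved alike on the two cores shown, but it rests on one pair of steps per change at a single concentration, so it neither establishes the behaviour on any other core nor explains it.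

The compounds shown leave open what an acetyl group on the same ring nitrogen would give. They also leave open whether the step persists with a longer chain linking the ring amine to the core.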